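Swapping an aromatic ring for a saturated one on the core

The compounds below may be only part of what the source reports. "The series", "measured", "known", "first", "only" and "open" are said of these compounds alone.

Going by these compounds, compound 1 `Cc1cc(C(=O)O)ccc1CN1CCC[C@H](O[C@H](CO)c2cc(Cl)cc(Cl)c2)[C@@H]1c1cccnc1` has no usable number in an assay on isolated protein for activation of cGMP-dependent protein kinase 1 (Homo sapiens), read by ADP-Glo, with stated times of 30 min and 2 h; a lower number here means that less compound is needed, a higher number that more compound is needed for the effect: its entry there reads "nd" (no result reported), so its standing in this assay is unknown. Two related compounds give some sense of the range. Compound 2 `Cc1cc(C(=O)O)ccc1CN1CC[C@H](OC(CO)c2cc(Cl)cc(Cl)c2)[C@@H]1c1ccccc1` gives 185000 nM in this assay, and compound 3 `O=C(O)c1ccc2nc(CN3CCC[C@H](O[C@H](CO)c4cc(Cl)cc(Cl)c4)[C@@H]3c3ccccc3)[nH]c2c1` gives 43000 nM. Both numbers are large, which means that a great deal of each compound is needed to activate the enzyme. Within the data shown here, no direct step between measured compounds is available, so nothing about the size of a change can be read from pairs in this set.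

Compound 4 `Cc1cc(C(=O)O)ccc1CN1CCC[C@H](O[C@H](CO)c2cc(Cl)cc(Cl)c2)[C@@H]1C1CCCCC1` differs from compound 1 in one place: cyclohexyl in place of pyridin-3-yl on a saturated ring carbon. Without a number for compound 1, the direction of this step cannot be judged; the expectation rests only on the weak values of compound 2 and compound 3. Compound 4 is expected to give about 60000 nM, within a range from 8000 nM to 300000 nM.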

Compound 4, half-maximal effective concentration: > 200000 nM
Compound 4 gave a limit, no number (the forecaster's own chance of this, stated with the estimate: 30%); middle value at least 3.3-fold (0.52 log units) from the limit.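

Compound 4 gives > 200000 nM in this assay, which is a limit and not a number. Among these compounds, compound 1 has no reported result there, so no step between compound 1 and compound 4 can be read. The compounds shown leave open whether cyclohexyl in place of pyridin-3-yl changes activation of the enzyme at all.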